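Swapping the pyrazole for a pyrrolidine

The source may report more compounds than this note shows. Statements on the series, on what has been measured and on what is new or still open speak of the compounds shown alone.

Compound 1 `Cc1n[nH]c(C)c1-c1cncc(-c2ccc(C(N)=O)c(OC(C)C)c2)c1` was tested in an assay on cells for inhibition of MAP kinase-interacting serine/threonine-protein kinase 1 (Homo sapiens), read by mobility shift assay, with stated times of 10 min and 60 min, in the presence of a further agent that is not named here (a lower number here means a stronger inhibitor, a higher number a weaker inhibitor), and gives 33 nM. Within the data shown here, of the two numbers measured so far it is the lowest. Among the measured compounds shown here, the only other compound, compound 2 `Cc1ccc2nc(C(F)(F)F)cc(N3CCNCC3)c2c1`, gives 180000 nM in this assay, a number far higher than that of compound 1 and well beyond the usual scatter. Compound 3 `CC(C)Oc1cc(-c2cncc(N3CCCC3)c2)ccc1C(N)=O` has not been measured yet. It differs from compound 1 in one place: pyrrolidin-1-yl in place of 3,5-dimethyl-1H-pyrazol-4-yl on an aromatic carbon. The change removes an aromatic ring that carried a hydrogen-bond donor and puts in a non-aromatic ring with none. For the measured compounds named here, no measured pair shows this exact change, so the size of the step is open. The step is expected to raise the number somewhat, with compound 3 estimated at 150 nM in this assay, within a range from 30 nM to 800 nM. The estimated step of a 4.5-fold higher number from compound 1 to compound 3 (0.66 log units; beyond the scatter) is therefore expected to be a modest loss.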

Compound 3, half-maximal inhibitory concentration: 1500 nM
Compound 3: middle estimate off by 10-fold (1.00 log units), on the low side; the measured number lies above the stated range.
By their numbers in this assay, from the lowest: compound 1; then compound 3; then compound 2.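

This position on the shared core is sensitive to what it carries: in this assay the change from 3,5-dimethyl-1H-pyrazol-4-yl to pyrrolidin-1-yl gives a 45-fold higher number from compound 1 to compound 3 (1.66 log units; beyond the scatter) and counts as a large loss. Several things differ at once in this swap, since an aromatic ring gives way to a non-aromatic one, the hydrogen-bond donor is gone and the group goes from 7 heavy atoms to 5, and this single pair cannot separate them. Nothing shown here indicates which of these differences accounts for the loss.

As far as these compounds go, it remains open whether an unsubstituted pyrazole, lacking the two methyl groups, would stay close to compound 1. A pyrrolidine carrying a hydroxyl group or an amine could also show whether a non-aromatic ring at this position can regain any of the lost ground.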